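Trimethoxyphenyl pyrazolyl chalcones: cytotoxicity at low concentration

The source may report more compounds than this note shows. Statements on the series, on what has been measured and on what is new or still open speak of the compounds shown alone.

Measured compounds:
compound 1 `COc1ccc(-c2cc(/C=C/C(=O)c3ccc(N)cc3)[nH]n2)cc1`: 97%
compound 2 `COc1ccc(C(=O)/C=C/c2cc(-c3cc(OC)c(OC)c(OC)c3)n[nH]2)cc1OC`: 102%
compound 3 `COc1ccc(-c2cc(/C=C/C(=O)c3ccc(N)cc3)[nH]n2)cc1OC`: 108%

In a functional assay on MOLT-4 cells (Homo sapiens) for cytotoxicity, read by sulforhodamine B assay, with a stated time of 48 h, tested at 0.01 uM (a lower number here means a stronger effect, a higher number a weaker effect of the compound at the concentration tested), compound 1 gives 97%, compound 2 gives 102% and compound 3 gives 108%. All three numbers sit close to full activity, so none of the compounds shows much of an effect at this concentration.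

Among the compounds with values here, the one single-point step that is measured runs from compound 1 to compound 3: methoxy in place of hydrogen on an aromatic carbon. It makes a number 11 percentage points higher from compound 1 to compound 3 (beyond the scatter).

Compound 4 `COc1cc(C(=O)/C=C/c2cc(-c3cc(OC)c(OC)c(OC)c3)n[nH]2)cc(OC)c1OC` is not yet measured. It differs from compound 2 in the same kind of change: methoxy in place of hydrogen on an aromatic carbon. Around the place the descriptions are not the same word for word: in compound 4 the entering group is also meta to a methoxy group, which is not part of the surroundings in the step from compound 1 to compound 3. The difference between the cores of compound 1 and compound 2 is not broken down here.

Because a number 11 percentage points higher from compound 1 to compound 3 (beyond the scatter) was modest and the starting number of compound 2 is 102%, the step from compound 2 to compound 4 is expected to be about a number 4 percentage points higher from compound 2 to compound 4 (within the scatter). Compound 4 is thus estimated at 106% in this assay, within 95% to 117%.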

Compound 4, a percentage reported as activity, at one concentration (the size of the read-out at that concentration, not a potency): 104%
The estimate for compound 4 lay 2 percentage points above the measured number; measured number inside the range.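

In this assay, methoxy in place of hydrogen on an aromatic carbon gives a number 2 percentage points higher from compound 2 to compound 4 (within the scatter), and set against the same change on the other core, the two steps do not come apart: the same change on two cores in this assay, a number 11 percentage points higher (beyond the scatter) from compound 1 to compound 3 and a number 2 percentage points higher (within the scatter) from compound 2 to compound 4, 9 percentage points apart, within the scatter of two such steps. Within the data shown here, at this single concentration, the change therefore carries from the core of compound 1 to the core of compound 2 with no difference that can be told from scatter, although only the step on the core of compound 1 lies beyond the scatter. Among these compounds, this does not show that the step has the same size on both cores: there are only two steps, the surroundings of the entering group are not the same, and all the numbers sit close to full activity.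

On these data alone, it remains open whether the two steps would still match at concentrations where the compounds show a clear effect. As far as these compounds go, it is also open whether a hydroxyl, a carboxylic acid or a longer chain at the same place would behave as methoxy does.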